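The source may report more compounds than this note shows. Statements on the series, on what has been measured and on what is new or still open speak of the compounds shown alone.

Compound 1 `O=c1ncn(Cc2c(F)cc(F)cc2F)c2ccc(Oc3ccccc3C(F)(F)F)cc12` in an ADME assay on Caco-2 cells (Homo sapiens) for permeability, in the apical to basolateral direction (a lower number here means that the compound crosses the layer more slowly, a higher number that the compound crosses the layer faster), gives 9.2 10^-6 cm/s. For compound 2 `O=c1ncn(Cc2c(F)cc(F)cc2F)c2ccc(Oc3cccc(-c4ccc5cc[nH]c5c4)c3C(F)(F)F)cc12` the entry in this assay reads "not determined" (no result reported), so no number of its own exists for it. Compound 3 `Cc1cc(-c2cccc(Oc3ccc4c(c3)c(=O)ncn4Cc3c(F)cc(F)cc3F)c2C(F)(F)F)cnc1N` differs from compound 2 in one place: 6-amino-5-methylpyridin-3-yl in place of 1H-indol-6-yl on an aromatic carbon. Within the data shown here, no measured pair shows how this change affects this assay, so neither its direction nor its size can be read from the data, and any step might also lie within the usual scatter. Compound 3 is estimated to give about 5 10^-6 cm/s in this assay, expected to fall between 1.5 10^-6 cm/s and 15 10^-6 cm/s.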

Compound 3, apparent permeability: 1.1 10^-6 cm/s
The estimate for compound 3 lay 4.5-fold (0.66 log units) above the measured number; measured number outside the range, below it.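

In this assay, putting 6-amino-5-methylpyridin-3-yl at this position, ortho to a trifluoromethyl group, gives an 8.4-fold lower number from compound 1 to compound 3 (0.92 log units; beyond the scatter). Among these compounds, this is the first measured step here, and it shows that a group at this position can slow passage across the cell layer by more than the usual scatter. Nothing available explains the drop.

As far as these compounds go, compound 2 has no number to set beside compound 3, so the effect of exchanging the two groups stays unknown. From the compounds shown here alone, whether a methoxy group or a carboxylic acid at this position would lower the number as far also remains open.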